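Three Weak Analogues and an Untested Chlorophenyl Variant

The source may report more compounds than this note shows. Statements on the series, on what has been measured and on what is new or still open speak of the compounds shown alone.

Measured in a functional assay on MCF7 cells (Homo sapiens) for cytotoxicity, read by MTT assay, with a stated time of 48 h; on this read-out lower numbers stand for stronger inhibition and higher numbers for weaker inhibition:
Compound 1, `COc1ccc(Nc2nc(-c3cccc(F)c3)nc3ccc(F)cc23)cc1`, gives 48400 nM.
Compound 2, `Fc1ccc(Nc2nc(-c3cccc(F)c3)nc3ccc(F)cc23)cc1`, reaches only the assay limit > 50000 nM.
Compound 3, `Fc1cccc(Nc2nc(-c3cccc(F)c3)nc3ccc(F)cc23)c1`, gives 48700 nM.

Compound 3 holds the higher of the two numbers given, with compound 1 nearest and within the scatter of it. Compound 2 sits at the limit (the limit of > 50000 nM in this assay, at which 1 of the 3 values shown sits), a ceiling of the test rather than a number.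

Compound 4, `Fc1cccc(-c2nc(Nc3ccccc3Cl)c3cc(F)ccc3n2)c1`, differs from compound 3 by 2-chlorophenyl in place of 3-fluorophenyl on a nitrogen on an aromatic ring. Two measured steps also swap the ring on that nitrogen: a 1.0-fold higher number from compound 1 to compound 3 (0.00 log units; within the scatter) and an at least 1.0-fold lower number from compound 2 to compound 3 (0.01 log units; that floor lies within the scatter), both within the scatter. Against that flat background, the step expected for compound 4 in the this assay is a 1.0-fold lower number from compound 3 to compound 4 (0.01 log units; within the scatter), nothing beyond the scatter. Compound 4 is therefore estimated at 48000 nM, ranging from 20000 nM to 100000 nM.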

Compound 4, half-maximal inhibitory concentration: > 50000 nM
Compound 4 ended at the assay's limit; the forecaster's own chance of this, stated with the estimate: 45%; at least 1.0-fold (0.01 log units) between middle value and limit.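

A chlorine-bearing ring, 2-chlorophenyl, on this nitrogen brings no gain in this assay: the data show an at least 1.0-fold higher number from compound 3 to compound 4 (0.01 log units; that floor lies within the scatter) and an at least 1.0-fold higher number from compound 1 to compound 4 (0.01 log units; that floor lies within the scatter), so neither step can be called a real change. The result for compound 4 is a limit, not a number, and the step from compound 2 cannot be read. Compound 4 joins compound 2 there: the limit of > 50000 nM in this assay, at which 2 of the 4 values shown sit.

On these data alone, whether an amine or a carboxylic acid on this ring would bring the number clearly down stays open. So does how far compound 4 lies past the limit.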